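The source may hold more compounds than are shown below. What is called first, only, known or untested is meant among the compounds shown, and "the series" means these compounds.

Compound 3 `CCCCc1[nH]c(=O)c(S(=O)(=O)c2ccc(-c3ccc(F)cc3)cc2)c(O)c1-c1c(OC)cccc1OC` stands in an ADME assay on microsomes from liver (Homo sapiens) for metabolic stability, using NADPH, with a stated time of 10 min (a higher number here means that more of the compound is left, a lower number that less of the compound is left), with the entry "not determined" (no result reported): no number was reported for it. Two related compounds do carry numbers in this assay. Compound 1 `CCCCc1nc(=O)c(S(=O)(=O)c2ccc(-c3ccc(F)nc3)cc2)c(O)n1-c1c(OC)cccc1OC` gives 100%, and compound 2 `CCCCc1nc(=O)c(S(=O)(=O)c2ccc(-n3cc(Cl)ccc3=O)cc2)c(O)n1-c1c(OC)cccc1OC` gives 94%. The step from compound 1 to compound 2, one six-membered aromatic ring with 1 hetero atom exchanged for another on an aromatic carbon, came out as a number 6 percentage points lower from compound 1 to compound 2 (within the scatter). Compound 4 `CCCCc1[nH]c(=O)c(S(=O)(=O)c2ccc(-c3ccncc3C)cc2)c(O)c1-c1c(OC)cccc1OC` differs from compound 3 by 3-methylpyridin-4-yl in place of 4-fluorophenyl on an aromatic carbon. That measured step resembles this change only loosely, and compound 3 itself has no number, so the expectation rests on compounds 1 and 2 alone. Compound 4 is therefore expected to give 85% in this assay, within a range from 60% to 100%.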

Compound 4, percent of the compound remaining: 80%
Estimate against measurement, compound 4: 5 percentage points above; low and high end bracket the measured number.
By their numbers in this assay, from the lowest: compound 4; then compounds 2 and 1 (each within the scatter of the next).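

No new step can be read between compound 3 and compound 4: compound 3 carries no number. Going by these compounds, what replacing 4-fluorophenyl with 3-methylpyridin-4-yl does to the percent remaining stays open, and no further data here bear on it.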